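The compounds below may be only part of what the source reports. "The series", "measured", "known", "first", "only" and "open" are said of these compounds alone.

Measured compounds:
- compound 1, `O=C(/C=C\Nc1ccc(Cl)cc1)c1cn(-c2ccccc2)nc1-c1ccccc1`, 11400 nM in a functional assay on U-87MG ATCC cells (Homo sapiens) for antiproliferative activity, read by MTT assay, with a stated time of 48 h; on this read-out higher numbers stand for weaker inhibition and lower numbers for stronger inhibition
- compound 2, `O=C(/C=C\Nc1ccc(Cl)cc1)c1cn(-c2ccccc2)nc1-c1ccc(F)cc1`, 8900 nM
- compound 3, `O=C(/C=C\Nc1ccc(F)cc1)c1cn(-c2ccccc2)nc1-c1ccc(Cl)cc1`, 17900 nM

Compound 3 gives the highest of the three numbers in this assay, yet its distance from compound 1 and from compound 2 stays within the usual scatter, so the three measured compounds cannot be told apart in strength. Within the data shown here, the only single-point step among them, a 1.3-fold lower number from compound 1 to compound 2 (0.11 log units; within the scatter), changes the phenyl ring attached to the shared core and also stays within the scatter.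

Compound 4, `O=C(/C=C\Nc1ccc(Cl)cc1)c1cn(-c2ccccc2)nc1-c1ccc(Cl)cc1`, differs from compound 3 by chloro in place of fluoro on an aromatic carbon. Among the measured compounds shown here, this exchange sits on the (4-fluorophenyl)amino part, a different ring from the one altered between compound 1 and compound 2, so no measured step speaks directly to it. The measured compounds together show that the halogen pattern shifts the numbers little, if at all. The step from compound 3 to compound 4 in this assay is therefore expected to be small, a 1.5-fold lower number from compound 3 to compound 4 (0.17 log units; within the scatter), with no direction beyond the scatter. Compound 4 is estimated at 12000 nM, within 5000 nM to 30000 nM.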

Compound 4, half-maximal inhibitory concentration: 13100 nM
Beside the measured number, compound 4's estimate is 1.1-fold (0.04 log units) below it; the measured number falls inside the stated range.
By their numbers in this assay, from the lowest: compounds 2, 1, 4 and 3 (each within the scatter of the next).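

In this assay, chloro in place of fluoro on the (4-fluorophenyl)amino ring gives a 1.4-fold lower number from compound 3 to compound 4 (0.14 log units; within the scatter) as its step, so fluoro and chloro cannot be told apart at this position, para to a large group. The other phenyl ring on the shared core now has readable halogen exchanges too: chloro in place of fluoro gives a 1.5-fold higher number from compound 2 to compound 4 (0.17 log units; within the scatter) as its step, and chloro in place of hydrogen gives a 1.1-fold higher number from compound 1 to compound 4 (0.06 log units; within the scatter) as its step, so hydrogen, fluoro and chloro there also stay within the scatter. No supporting measurement is available to explain these results.

The compounds shown leave open whether a methoxy group, an amine or a carboxylic acid at either para position would move the number beyond the scatter. On these data alone, whether the same flat picture holds in other cell lines also remains open.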